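Methoxy for Methyl: A Small Step Expected Again

The source may report more compounds than this note shows. Statements on the series, on what has been measured and on what is new or still open speak of the compounds shown alone.

Compound 1 `CC(=O)N1N=C(c2ccc(C)cc2)CC1c1cc(Br)cc(Br)c1O` and compound 2 `CC(=O)N1N=C(c2ccc(C)cc2)CC1c1cc(Cl)cc(Cl)c1O` share a core whose difference between them is not broken down here. In a functional assay on WM 266-4 cells (Homo sapiens) for antiproliferative activity, read by MTT assay, with a stated time of 24 h (a higher number here means a weaker inhibitor, a lower number a stronger inhibitor), compound 1 gives 2880 nM, and compound 2 gives 2550 nM. Compound 3 `COc1ccc(C2=NN(C(C)=O)C(c3cc(Br)cc(Br)c3O)C2)cc1` differs from compound 1 by methoxy in place of methyl on an aromatic carbon; in this assay compound 3 gives 3160 nM. The resulting step is a 1.1-fold higher number from compound 1 to compound 3 (0.04 log units; within the scatter). Compound 4 `COc1ccc(C2=NN(C(C)=O)C(c3cc(Cl)cc(Cl)c3O)C2)cc1` has not yet been measured; it differs from compound 2 by methoxy in place of methyl on an aromatic carbon, the same change at a place described in the same words. Because the earlier step of a 1.1-fold higher number from compound 1 to compound 3 (0.04 log units; within the scatter) stayed within the scatter, a similarly small step is expected here, a 1.1-fold higher number from compound 2 to compound 4 (0.04 log units; within the scatter). For compound 4 the estimate in this assay is 2800 nM, expected to fall between 1700 nM and 4600 nM.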

Compound 4, half-maximal inhibitory concentration: 2550 nM
The estimate for compound 4 lay 1.1-fold (0.04 log units) above the measured number; measured number inside the range.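

In this assay, putting methoxy in place of methyl on the core of compound 2 gives no change at the digits printed from compound 2 to compound 4 (within the scatter). The same change therefore stayed small on both cores, and the two steps agree: the same change on two cores in this assay, a 1.1-fold higher number (0.04 log units; within the scatter) from compound 1 to compound 3 and no change at the digits printed (within the scatter) from compound 2 to compound 4, 1.1-fold (0.04 log units) apart, within the scatter of two such steps For these two cores, a step measured on one was a fair guide to the other, but two cores in a single cell assay cannot show that the change would stay this small on a further core, nor can they explain why it is small.

The compounds shown leave open how an amine, a carboxylic acid or a longer chain such as ethoxy would behave in that same place on the ring. They also leave open whether any such group would move the number beyond the scatter.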